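The source may report more compounds than this note shows. Statements on the series, on what has been measured and on what is new or still open speak of the compounds shown alone.

Measured compounds:
compound 1, `O=c1cc(/C=C/c2ccc(O)cc2)oc2cc(O)ccc12`, 92000 nM
compound 2, `O=c1cc(/C=C/c2ccccc2)oc2cc(O)cc(O)c12`, 5700 nM

Both were tested in a functional assay; a lower number here means a stronger inhibitor, a higher number a weaker inhibitor. Compound 1 gives 92000 nM, while compound 2 gives 5700 nM. Of the two numbers, compound 2 has the lowest; the number for compound 1 is higher by a margin well beyond the usual scatter. The two structures differ in more than one place, so no single change can be held responsible for that gap.

Compound 3, `O=c1cc(/C=C/c2ccc(O)cc2)oc2cc(O)cc(O)c12`, has not yet been measured. It differs from compound 2 by hydroxy in place of hydrogen on an aromatic carbon. Going by the values given here, no measured pair shows this single change on its own, so the step can only be guessed. Compound 3 is expected to stay close to compound 2, with a step of a 1.2-fold higher number from compound 2 to compound 3 (0.09 log units; within the scatter), in either direction and not clearly beyond the scatter. On that basis, compound 3 is estimated at 7000 nM, within a range from 1500 nM to 30000 nM.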

Compound 3, half-maximal inhibitory concentration: 8500 nM
Estimate against measurement, compound 3: 1.2-fold (0.08 log units) below, within the range that was stated.
By their numbers in this assay, from the lowest: compounds 2 and 3 (each within the scatter of the next); then compound 1.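

In this assay, hydroxy in place of hydrogen on the six-membered aromatic ring of carbon only, para to a large group, turns phenyl into 4-hydroxyphenyl and gives a 1.5-fold higher number from compound 2 to compound 3 (0.17 log units; within the scatter), so this position accepts the hydroxy with no clear gain or loss. Hydroxy in place of hydrogen on an aromatic carbon of the shared core behaves differently, with an 11-fold lower number from compound 1 to compound 3 (1.03 log units; beyond the scatter). Going by these compounds alone, of the two places where compound 1 and compound 2 differ, only the one on the core therefore shows a step beyond the scatter.

Going by these compounds, it remains open whether a different group at the para position, such as methoxy or an amine, would also be accepted. On these data alone, it is also open whether the hydroxy on the core would have as large an effect alongside a plain phenyl.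

No measurement available here explains either step.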